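A few compounds are considered here, and "the series" means these few. Any claim that something is new, unique, unknown or untested is made for them only; others in the source may bear on it.

Measured in a physicochemical assay for solubility; on this read-out higher numbers stand for higher solubility and lower numbers for lower solubility:
- Compound 1 `CNC(=O)c1cc(C(=O)N[C@H]2[C@@H]3COC[C@@H]32)cc2c1OC[C@H]2c1cccc(OC)c1`: >= 186 ug/mL
- Compound 2 `CNC(=O)c1cc(C(=O)N[C@H]2[C@@H]3COC[C@@H]32)cc2c1OC[C@H]2c1ccccc1`: >= 165 ug/mL

Compound 2 stands at >= 165 ug/mL, which is a limit of the assay and not a number. Compound 1 stands at >= 186 ug/mL, and that too is a limit. Neither compound has an exact reading in this assay, so the two cannot be ranked.

Among the measured compounds shown here, the one measured step puts hydrogen in place of methoxy on an aromatic carbon, and it is a step that the two limits leave unreadable from compound 1 to compound 2. The next compound is compound 3 `CNC(=O)c1cc(C(=O)N[C@H]2[C@@H]3COC[C@@H]32)cc2c1OC[C@H]2c1ccncc1`, which carries pyridin-4-yl in place of phenyl on a saturated ring carbon. The measured step is a different change and has no readable size, so it offers no measured guide to this one.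

The estimate therefore rests on the limit of compound 2, >= 165 ug/mL, alone. No step beyond the usual scatter is expected, and no direction can be given. The expected step is a step that the limit leaves unreadable from compound 2 to compound 3. For compound 3 the expected value is 175 ug/mL, with an estimated range from 100 ug/mL to 300 ug/mL, and it may well be reported as a limit too.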

Compound 3, solubility: >= 184 ug/mL
Compound 3 was reported as a limit; the forecaster's own chance of this, stated with the estimate: 75%; middle value at least 1.0-fold (0.02 log units) from the limit.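

In this assay compound 3 gives >= 184 ug/mL, which is a limit and not a number. Among the compounds shown here, compound 1 and compound 2 also stand at limits, and no step among compound 1, compound 2 and compound 3 can be read. The compounds shown leave open where the true solubility of each one lies, and whether pyridin-4-yl in place of phenyl changes it at all.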